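Chain extension of the phenoxyalkyl tail, from compound 2 to compound 3

A few compounds are considered here, and "the series" means these few. Any claim that something is new, unique, unknown or untested is made for them only; others in the source may bear on it.

Among the measured compounds shown here, compound 2 `N[C@@H](COP(=O)(O)OCCCOC(=O)CCc1ccccc1OCCCCOc1ccccc1)C(=O)O` gives 6.1% in an assay on cells for agonist activity at probable G-protein coupled receptor 34 (Mus musculus), with a stated time of 1 h (a lower number here means a smaller maximal response, a higher number a larger maximal response), the lower of the two numbers known; its nearest neighbour is compound 1 `CCCCCCCCCCCOc1ccccc1CCC(=O)OCCCOP(=O)(O)OC[C@H](N)C(=O)O`, which in this assay gives 14.6%, and that step of a number 8.5 percentage points lower from compound 1 to compound 2 (within the scatter) stays within the scatter. Compound 3 `N[C@@H](COP(=O)(O)OCCCOC(=O)CCc1ccccc1OCCCCCCOc1ccccc1)C(=O)O` differs from compound 2 by 2-phenoxyethyl in place of phenoxy on a saturated chain carbon, four bonds along the chain from an oxygen on an aromatic ring. For the measured compounds named here, the only measured step, from compound 1 to compound 2, concerned a different exchange at the same place and was small, so the chain lengthening here is expected to yield no step beyond the scatter, a number 3.9 percentage points higher from compound 2 to compound 3 (within the scatter). Compound 3 is therefore estimated at 10%, within 2% to 25%.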

Compound 3, largest response reached (Emax), in percent of the reference or control that the assay uses: 20.7%
Estimate against measurement, compound 3: 10.7 percentage points below; the range from low to high includes it.
By their numbers in this assay, from the lowest: compounds 2, 1 and 3 (each within the scatter of the next, the first and the last beyond it).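

Lengthening phenoxy to 2-phenoxyethyl, on a saturated chain carbon four bonds along the chain from an oxygen on an aromatic ring, gives the first step beyond the scatter at this position in this assay, a number 14.6 percentage points higher from compound 2 to compound 3 (beyond the scatter), so the maximal response here depends on tail length. The same tail does not separate from the plain alkyl tail, with a number 6.1 percentage points higher from compound 1 to compound 3 (within the scatter). Nothing available gives a reason for this step. Going by these compounds, whether a longer chain raises the response further, or an amine or carboxylic acid in place of the terminal phenoxy keeps it, remains open.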